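This account rests on a few compounds, and the source may have more. Where it says the series, first, only, none or still open, it means among the compounds named here.

Measured in a functional assay on HCT-116 cells (Homo sapiens) for inhibition, read by colorimetric assay, with a stated time of 3 days; on this read-out higher numbers stand for weaker inhibition and lower numbers for stronger inhibition:

Compound 1 `COc1ccc(OC)c(NC(=O)CCCCCCNC(=O)C(O)(O)C(F)(F)F)c1` gives 3870 nM
Compound 2 `COc1ccccc1NC(=O)CCCCCCNC(=O)C(O)(O)C(F)(F)F` gives 10100 nM
Compound 3 `CC(=O)C(=O)NCCCCCC(=O)Nc1ccccc1` gives > 100000 nM, a limit of the assay and not a number

Of the two numeric values in this assay compound 2 holds the higher one at 10100 nM. Within the data shown here, the nearest value belongs to compound 1, and the gap between them is the only measured step: a 2.6-fold higher number from compound 1 to compound 2 (0.42 log units; beyond the scatter). That step is modest but beyond the scatter, and it is hydrogen in place of methoxy on an aromatic carbon.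

Compound 4 `O=C(CCCCCCNC(=O)C(O)(O)C(F)(F)F)Nc1cccc(Br)c1` has no reading yet. Relative to compound 2 the change is 3-bromophenyl in place of 2-methoxyphenyl on an amide-type nitrogen, in words 3-bromophenyl in place of 2-methoxyphenyl on an amide-type nitrogen. Among the measured compounds shown here, the only guide is the modest step of a 2.6-fold higher number from compound 1 to compound 2 (0.42 log units; beyond the scatter), and it bears on this change only indirectly, since no bromine-bearing compound has been measured. A large move in this assay is therefore not expected, and the direction is poorly defined. The expected step is a 1.4-fold lower number from compound 2 to compound 4 (0.16 log units; within the scatter), which stays within the scatter. The estimate for compound 4 is 7000 nM, with an expected range from 2500 nM to 20000 nM.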

Compound 4, half-maximal inhibitory concentration: 3060 nM
Compound 4: middle estimate off by 2.3-fold (0.36 log units), on the high side; the measured number falls inside the stated range.
By their numbers in this assay, from the lowest: compounds 4 and 1 (each within the scatter of the next); then compound 2. At a limit, above all of these: compound 3.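

In this assay, among these compounds, 3-bromophenyl in place of 2-methoxyphenyl on the amide-type nitrogen gives a 3.3-fold lower number from compound 2 to compound 4 (0.52 log units; beyond the scatter), a modest step but one beyond the scatter, and the first reading here for an aryl group with no methoxy and no hydrogen-bond acceptor. A methoxy group on this ring is therefore not needed to reach the low end of the values in this series, since compound 4 at 3060 nM and compound 1 at 3870 nM lie within the scatter of each other, even though their rings carry different substituents. Nothing measured here accounts for the step itself.

Going by these compounds, whether the step follows the bromine itself or its place on the ring remains open, as a single pair cannot separate the two. Also open, on these data alone, is how a chlorine, a nitrile or an amine in place of the bromine would read in this assay, and so whether this position tolerates groups well beyond the two kinds of substituent seen so far.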